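The source may report more compounds than this note shows. Statements on the series, on what has been measured and on what is new or still open speak of the compounds shown alone.

In a functional assay on HUVEC cells (Homo sapiens), read by scintillation counting and thymidine incorporation, with a stated time of 24 h (a lower number here means a stronger inhibitor, a higher number a weaker inhibitor), compound 1 `CCC(C)n1ncn(-c2ccc(N3CCN(c4ccc(OC[C@@H]5CO[C@@](Cn6cnc(C)n6)(c6ccc(Cl)cc6Cl)O5)cc4)CC3)cc2)c1=O` gives 272 nM and compound 2 `CCC(C)n1ncn(-c2ccc(N3CCN(c4ccc(OC[C@@H]5CO[C@@](Cn6cnc(C(F)(F)F)n6)(c6ccc(Cl)cc6Cl)O5)cc4)CC3)cc2)c1=O` gives 270 nM. Among the compounds with values here, compound 2 thus stands level with compound 1, the only other measured number. Within the data shown here, the single measured step is a 1.0-fold lower number from compound 1 to compound 2 (0.00 log units; within the scatter), with trifluoromethyl in place of methyl on an aromatic carbon. Compound 3 `CCC(C)n1ncn(-c2ccc(N3CCN(c4ccc(OC[C@@H]5CO[C@@](Cn6cc(C)nc6C)(c6ccc(Cl)cc6Cl)O5)cc4)CC3)cc2)c1=O` carries 2,4-dimethyl-1H-imidazol-1-yl in place of 3-(trifluoromethyl)-1H-1,2,4-triazol-1-yl on a saturated chain carbon bound to a saturated ring carbon. Among the measured compounds shown here, the measured step bears on this only in part, since it changed a substituent on the ring that now leaves, and no measured step exchanges the ring itself. No shift beyond the scatter is therefore expected in this assay, and no direction can be favoured. The estimated step is a 1.0-fold higher number from compound 2 to compound 3 (0.02 log units; within the scatter). For compound 3 the expected value is 280 nM, within an estimated range from 100 nM to 750 nM.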

Compound 3, half-maximal inhibitory concentration: 492 nM
Beside the measured number, compound 3's estimate is 1.8-fold (0.24 log units) below it; measured number inside the range.
By their numbers in this assay, from the lowest: compounds 2, 1 and 3 (each within the scatter of the next).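

In this assay, exchanging the whole ring on the saturated chain carbon bound to a saturated ring carbon gives a 1.8-fold higher number from compound 2 to compound 3 (0.26 log units; within the scatter) for 2,4-dimethyl-1H-imidazol-1-yl in place of 3-(trifluoromethyl)-1H-1,2,4-triazol-1-yl, and a 1.8-fold higher number from compound 1 to compound 3 (0.26 log units; within the scatter) for the same group in place of 3-methyl-1H-1,2,4-triazol-1-yl. Within the data shown here, the one earlier step changed only a substituent on the triazolyl ring, whereas these two steps show that, across the three compounds, the ring itself can also be exchanged at this place without a shift beyond the scatter. Nothing available explains these numbers.

Going by these compounds, whether a group without a ring at this place, such as a primary amine or a carboxylic acid, would also stay within the scatter remains open. So does how an unsubstituted 1H-imidazol-1-yl would read here.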